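A few compounds are considered here, and "the series" means these few. Any claim that something is new, unique, unknown or untested is made for them only; others in the source may bear on it.

Measured so far in a functional assay on HeLa cells (Homo sapiens) for antiproliferative activity, read by MTT assay, with a stated time of 48 h; on this read-out lower numbers stand for stronger inhibition and higher numbers for weaker inhibition:
Compound 1 `CN(C)CCCn1c(N)c(-c2nc3ccccc3o2)c2nc(C#N)c(C#N)nc21` gives 11200 nM
Compound 2 `CN(C)CCCCn1c(N)c(-c2nc3ccccc3o2)c2nc(C#N)c(C#N)nc21` gives 1950 nM
Compound 3 `CCN(CC)CCCCn1c(N)c(-c2nc3ccccc3o2)c2nc(C#N)c(C#N)nc21` gives 6420 nM

The number for compound 1 cannot be told apart from one neighbour (a 1.7-fold lower number from compound 1 to compound 3 (0.24 log units; within the scatter)) but lies clear of the other (a 5.7-fold lower number from compound 1 to compound 2 (0.76 log units; beyond the scatter)). Compound 4 `CN(C)CCCn1c(N)c(-c2nc3ccccc3n2C)c2nc(C#N)c(C#N)nc21` keeps the core and the 3-(dimethylamino)propyl group of compound 1 and changes one group only, on an aromatic carbon next to the ring atom that bears an amino group (1-methyl-1H-benzimidazol-2-yl in place of 1,3-benzoxazol-2-yl on an aromatic carbon). Among the compounds with values here, no measured step touches this place. All of them sit on the amine chain, including the remaining one (a 3.3-fold higher number from compound 2 to compound 3 (0.52 log units; beyond the scatter)). These steps show how far numbers have moved within this small set, but they give no direction for the new group. In this assay no step beyond the scatter is therefore expected, though the uncertainty is wide on both sides. The estimated step (a 1.2-fold lower number from compound 1 to compound 4 (0.09 log units; within the scatter)) is small. For compound 4 the expected value is 9000 nM, with an estimated range from 2800 nM to 30000 nM.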

Compound 4, half-maximal inhibitory concentration: 4320 nM
Compound 4: the middle estimate sits 2.1-fold (0.32 log units) above what was measured; measured number inside the range.
By their numbers in this assay, from the lowest: compound 2; then compounds 4, 3 and 1 (each within the scatter of the next, the first and the last beyond it).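

In this assay, within the data shown here, the aromatic carbon that no earlier step touched proves able to move the number: 1-methyl-1H-benzimidazol-2-yl in place of 1,3-benzoxazol-2-yl gives a 2.6-fold lower number from compound 1 to compound 4 (0.41 log units; beyond the scatter) as a modest step. Activity in this series therefore depends on more than the amine chain. Both groups hold a five-membered aromatic ring with 2 hetero atoms and a six-membered aromatic ring of carbon only, with equal counts of hydrogen-bond donors and acceptors, so those shared counts do not describe what changed, and nothing available explains the shift.

On these data alone, it remains open how an unmethylated 1H-benzimidazol-2-yl or a 1,3-benzothiazol-2-yl would compare at this position. As far as these compounds go, it is also open whether 1-methyl-1H-benzimidazol-2-yl would lower the number similarly when paired with the four-carbon amine chain of compound 2.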